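Removing a Fluorine From a Weak Imidazole Inhibitor

This account rests on a few compounds, and the source may have more. Where it says the series, first, only, none or still open, it means among the compounds named here.

Measured compounds:
- compound 1, `Cc1cscc1-c1ccc(Cn2ccnc2)cc1`, 0%
- compound 2, `Fc1ccc(-c2ccc(Cn3ccnc3)cc2)cn1`, 4%

Two compounds share a benzylimidazole core joined to an aromatic ring. In an assay for inhibition of steroid 17-alpha-hydroxylase/17,20 lyase (Homo sapiens), using NADPH, tested at 0.2 uM (on this read-out higher numbers stand for a stronger effect at the one concentration tested and lower numbers for a weaker effect), compound 1 gives 0%, and in this assay compound 2 gives 4%. The gap between the two values lies within the usual scatter of repeated measurements, so neither compound can be called more or less effective than the other; both sit close to the floor of the read-out.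

Compound 3, `c1cncc(-c2ccc(Cn3ccnc3)cc2)c1`, has not yet been measured. It differs from compound 2 in one place: hydrogen in place of fluoro on an aromatic carbon. Among the compounds with values here, no step between measured compounds has been worked out here, so the size of this change is not known from a direct comparison.

Because compound 2 gives 4% and its neighbour compound 1 also sits near zero, compound 3 is expected to remain near the bottom of the scale, with an expected step of a number 1 percentage points lower from compound 2 to compound 3 (within the scatter), that is, none beyond the scatter. The estimate for compound 3 in this assay is 3%, within a range from 0% to 15%.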

Compound 3, a percentage reported as inhibition, at one concentration (the size of the read-out at that concentration, not a potency): 2%
Compound 3: middle estimate off by 1 percentage points, on the high side, and the stated range covers the measured number.
By their numbers in this assay, from the lowest: compounds 1, 3 and 2 (each within the scatter of the next).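

In this assay, putting hydrogen in place of fluoro on the aromatic carbon next to the ring nitrogen gives a number 2 percentage points lower from compound 2 to compound 3 (within the scatter), so at this position the fluoro group makes no difference that can be read at the one concentration tested. A much larger change to the same core, pyridin-3-yl in place of 4-methylthiophen-3-yl, gives a number 2 percentage points higher from compound 1 to compound 3 (within the scatter), so replacing the whole ring also stays inside the scatter, and neither step separates the compounds at the floor of the read-out. Nothing measured here offers an explanation for this flat result.

With all three numbers this close to zero, a real effect of fluoro could be hidden, since a single-concentration read-out near the floor is not a potency and cannot show small differences between weak compounds. On these data alone, it remains open whether a methoxy group, a chlorine atom or an amine on that same aromatic carbon would lift the number clear of the scatter, or whether this position has little influence on the read-out whatever group it carries.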